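Swapping the Ester Group on a Selenium-Bearing Quinoline Analogue

The source may report more compounds than this note shows. Statements on the series, on what has been measured and on what is new or still open speak of the compounds shown alone.

Measured compounds:
compound 1, `OCC#CCSc1cnc2ccccc2c1SCC#CCCl`: 43.4 ug/mL
compound 2, `CSc1cnc2ccccc2c1[Se]CC#CCOC(=O)/C=C/c1ccccc1`: 3.1 ug/mL
compound 3, `C#CCSc1cnc2ccccc2c1SCC#CCCl`: 52.8 ug/mL

In a functional assay on B16 cells (Mus musculus) for antiproliferative activity, with a stated time of 72 h (on this read-out higher numbers stand for weaker inhibition and lower numbers for stronger inhibition), compound 2 gives the lowest number of the three, with compound 1 at 43.4 ug/mL and compound 3 at 52.8 ug/mL both well beyond the scatter from it. For the measured compounds named here, the only single-place comparison among measured compounds is a 1.2-fold higher number from compound 1 to compound 3 (0.09 log units; within the scatter), a change that touches a triple-bonded carbon rather than the ester end and is too small to count.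

Compound 4, `CSc1cnc2ccccc2c1[Se]CC#CCOC(=O)c1ccccc1`, differs from compound 2 by phenyl in place of 2-phenylethenyl on a carbonyl carbon. Going by the values given here, no measured step in this assay tests a change at a carbonyl carbon, so the closest guidance is simply the value of compound 2 itself.

With nothing pointing either way, compound 4 is expected to stay close to compound 2, a step of about a 1.3-fold higher number from compound 2 to compound 4 (0.11 log units; within the scatter) in this assay, not beyond the scatter. The estimate for compound 4 is therefore 4 ug/mL, within a range from 1.5 ug/mL to 11 ug/mL.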

Compound 4, concentration for 50% inhibition: 2.1 ug/mL
Compound 4: middle estimate off by 1.9-fold (0.28 log units), on the high side; the measured number falls inside the stated range.
By their numbers in this assay, from the lowest: compounds 4 and 2 (each within the scatter of the next); then compounds 1 and 3 (each within the scatter of the next).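

For the compounds shown here, until now, the only single-place step sat on a triple-bonded carbon, so nothing had tested the ester end of these molecules. In this assay the step on the carbonyl carbon, with phenyl in place of 2-phenylethenyl, is a 1.5-fold lower number from compound 2 to compound 4 (0.17 log units; within the scatter) and stays within the scatter, so for this pair, losing the double bond outside aromatic rings leaves the read-out unchanged while the six-membered aromatic ring of carbon stays in place. No supporting data explain why the two groups read alike.

From the compounds shown here alone, whether this carbonyl carbon also accepts a group without an aromatic ring, such as an amine or a longer chain, remains open. Compound 1 and compound 3 differ from compound 2 and compound 4 in more than one place, so they cannot show what selenium or the ester contributes alone.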